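Fluoro for methyl on the sulfonamide aryl of compound 3

The source may report more compounds than this note shows. Statements on the series, on what has been measured and on what is new or still open speak of the compounds shown alone.

Measured so far:
compound 1, `CC(C)(C)c1cn(C[C@H](O)[C@H]2OC(=O)C(OCc3ccccc3)=C2OCc2ccccc2)nn1`: 29200 nM
compound 2, `COc1ccc(-c2cn(C/C=C3\OC(=O)C(OCc4ccccc4)=C3OCc3ccccc3)nn2)cc1`: > 100000 nM
compound 3, `Cc1ccc(S(=O)(=O)NCc2cn(C[C@H](O)[C@H]3OC(=O)C(OCc4ccccc4)=C3OCc3ccccc3)nn2)cc1`: 24900 nM

In a functional assay on HepG2 cells (Homo sapiens) for antiproliferative activity, read by MTT assay, with a stated time of 72 h (a lower number here means a stronger inhibitor, a higher number a weaker inhibitor), compound 1 gives 29200 nM. Compound 3 gives 24900 nM in this assay. The step of a 1.2-fold lower number from compound 1 to compound 3 (0.07 log units; within the scatter) shows that these two numbers sit within the scatter of each other, so no order between compound 1 and compound 3 can be read from them. The value of compound 2 in this assay is a limit, > 100000 nM, not a number, as noted in the limit of > 100000 nM in this assay, at which 1 of the 3 values shown sits.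

Compound 4, `O=C1O[C@H]([C@@H](O)Cn2cc(CNS(=O)(=O)c3ccc(F)cc3)nn2)C(OCc2ccccc2)=C1OCc1ccccc1`, has not yet been measured in this assay. The change from compound 3 to compound 4 is fluoro in place of methyl on an aromatic carbon. No measured step touches this part of the molecule: the only step shown, a 1.2-fold lower number from compound 1 to compound 3 (0.07 log units; within the scatter), concerns the group on the triazole carbon and was itself within the scatter. The step from compound 3 to compound 4 is therefore expected to stay within the scatter, a 1.0-fold higher number from compound 3 to compound 4 (0.00 log units; within the scatter). Compound 4 is estimated at 25000 nM, in the range 10000 nM to 70000 nM.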

Compound 4, half-maximal inhibitory concentration: 18300 nM
Estimate against measurement, compound 4: 1.4-fold (0.14 log units) above, and the stated range covers the measured number.
By their numbers in this assay, from the lowest: compounds 4, 3 and 1 (each within the scatter of the next). At a limit, above all of these: compound 2.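

In this assay, for the compounds shown here, the step of a 1.4-fold lower number from compound 3 to compound 4 (0.13 log units; within the scatter) gives the first reading at this position, and it shows that fluoro in place of methyl on the aromatic carbon para to a large group brings no readable change. The step of a 1.6-fold lower number from compound 1 to compound 4 (0.20 log units; within the scatter) also means that (((4-fluorophenyl)sulfonyl)amino)methyl and tert-butyl on an aromatic carbon cannot be told apart by these numbers. Nothing available beyond the numbers themselves bears on this result.

Going by these compounds, whether an amine or a carboxylic acid in place of fluoro on this aromatic carbon would carry the number beyond the scatter remains open. It is equally open whether an amide in place of the sulfonamide would leave the number within the scatter of these compounds.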